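The compounds below may be only part of what the source reports. "The series", "measured", "known", "first", "only" and "open" are said of these compounds alone.

Of the compounds shown here, two of a shared core have been measured in an assay on HEK293 cells for inhibition of Voltage-dependent T-type calcium channel subunit alpha-1G (Homo sapiens), read by patch clamp; a lower number here means a stronger inhibitor, a higher number a weaker inhibitor. Compound 1, `CCCc1nc(-c2ccccc2)c(CNCCN2CCN(C(c3ccccc3)c3ccccc3)CC2)o1`, carries a diphenylmethyl group on the terminal nitrogen of its piperazine, and in this assay compound 1 gives 7470 nM. Compound 2, `CCCc1nc(-c2ccccc2)c(CNCCN2CCN(c3ccc(Cl)cc3)CC2)o1`, has a 4-chlorophenyl group in that position, and in this assay compound 2 gives 2820 nM. Of the two numbers, compound 2 stands lowest, and the gap to compound 1 lies beyond the usual scatter of repeated measurements, so compound 2 is the stronger inhibitor of the pair.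

Compound 3, `CCCc1nc(-c2ccccc2)c(CNCCN2CCN(c3ccccc3)CC2)o1`, differs from compound 2 in one place: hydrogen in place of chloro on an aromatic carbon. Within the data shown here, no measured pair in this set isolates that change, so its effect has to be judged without a reference step. The change removes a single heavy atom from the group that distinguishes compound 2 from compound 1, and the remainder of the structure is untouched. A modest step is expected, more likely toward a higher number than a lower one, and quite possibly within the scatter. For compound 3 the expected value in this assay is 4500 nM, with a range from 2000 nM to 10000 nM, an estimated step of a 1.6-fold higher number from compound 2 to compound 3 (0.20 log units; within the scatter).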

Compound 3, half-maximal inhibitory concentration: 10300 nM
The estimate for compound 3 lay 2.3-fold (0.36 log units) below the measured number; the whole stated range lies below it.
By their numbers in this assay, from the lowest: compound 2; then compounds 1 and 3 (each within the scatter of the next).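

In this assay, among these compounds, the chloro group proves to matter at this place on the aromatic ring: hydrogen in place of chloro gives a 3.7-fold higher number from compound 2 to compound 3 (0.56 log units; beyond the scatter), and this is the only step in the set that isolates a single change on the ring. Among the compounds shown here, without the chloro group, the plain phenyl no longer sets its compound apart from the diphenylmethyl compound, since compound 3 at 10300 nM and compound 1 at 7470 nM lie within the scatter of each other, so the advantage of compound 2 over compound 1 depends on the chloro group and not on the phenyl ring alone. No measurement here bears on what lies behind this step, which stands as an observation only.

The compounds shown leave open whether this step is particular to chlorine or would also appear with a fluoro, bromo, methyl or methoxy group at the same place on the ring. They also leave open whether the chloro group would keep its effect with a longer chain on the shared core.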